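Swapping an aromatic ring for a short chain on the carbonyl

This account rests on a few compounds, and the source may have more. Where it says the series, first, only, none or still open, it means among the compounds named here.

Measured so far:
- compound 1, `CC(C)CC(=O)N1CCc2cc(CNC(=O)c3cccnc3)ccc21`: 86%
- compound 2, `CCCC(=O)NCc1ccc2c(c1)CCN2C(=O)CC(C)C`: 64%
- compound 3, `CC(C)CC(=O)N1CCc2cc(CNC(=O)c3cccs3)ccc21`: 100%

All three share one core and differ only in the group on a carbonyl carbon whose other neighbour is an amide-type nitrogen. In an assay on HEK293 cells for inhibition of Indoleamine 2,3-dioxygenase 1 (Homo sapiens), tested at 10 uM (on this read-out lower numbers stand for less inhibition and higher numbers for more inhibition at the one concentration tested (going by the name of the read-out)), compound 3 stands highest of the three, with compound 1 nearest and compound 2 furthest, and both gaps lie beyond the usual scatter.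

The next compound is compound 4, `COCC(=O)NCc1ccc2c(c1)CCN2C(=O)CC(C)C`. Its difference from compound 3 is methoxymethyl in place of thiophen-2-yl on a carbonyl carbon. For the measured compounds named here, two measured steps bear on this. The step of a number 36 percentage points higher from compound 2 to compound 3 (beyond the scatter) shows what replacing a plain chain, propyl, with thiophen-2-yl on that carbonyl carbon did, and the step of a number 14 percentage points higher from compound 1 to compound 3 (beyond the scatter) shows the smaller gain from another ring. Going back from thiophen-2-yl to a short chain, methoxymethyl, therefore points to a large drop in this assay, roughly undoing the gain seen between compound 2 and compound 3, since both chains lack a ring.

For compound 4 the expected value is 55%, with a range from 30% to 80%, which means an estimated step of a number 45 percentage points lower from compound 3 to compound 4 (beyond the scatter).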

Compound 4, a percentage reported as inhibition, at one concentration (the size of the read-out at that concentration, not a potency): 20%
The estimate for compound 4 lay 35 percentage points above the measured number, outside the stated range (below it).
By their numbers in this assay, from the lowest: compound 4; then compound 2; then compound 1; then compound 3.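

In this assay, two ring-free groups on this carbonyl carbon turn out not to be equivalent: methoxy in place of ethyl on a saturated chain carbon bound to a carbonyl carbon gives a number 44 percentage points lower from compound 2 to compound 4 (beyond the scatter) in this series, so lacking a ring does not by itself set the level of inhibition. Measured against the two rings, methoxymethyl gives a number 80 percentage points lower from compound 3 to compound 4 (beyond the scatter) and a number 66 percentage points lower from compound 1 to compound 4 (beyond the scatter) here, which leaves compound 4 lowest of the four. With the rest of the structure unchanged, this one position therefore spans a much wider range than the first three compounds revealed. No accompanying measurement explains the drop.

An amine or a carboxylic acid at the end of a chain on this carbonyl carbon, or a longer chain, could show whether compound 4 reflects something specific to methoxy or a wider sensitivity to changes in the chain. A phenyl ring in the same place could show whether the high numbers of compound 1 and compound 3 extend to a ring with no hetero atom.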